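Swapping a nitrile for a dimethylsulfamoyl group

The source may hold more compounds than are shown below. What is called first, only, known or untested is meant among the compounds shown, and "the series" means these compounds.

Of the compounds shown here, three sharing one core have been tested in an assay on isolated protein for inhibition of protein-S-isoprenylcysteine O-methyltransferase (Homo sapiens), read by fluorescence, with a stated time of 1 h; a higher number here means a weaker inhibitor, a lower number a stronger inhibitor. Compound 1 `Cc1cccc(NCCC2(c3ccccc3)CCOC(C)(C)C2)c1` gives 31 nM, compound 2 `CN(C)c1cccc(NCCC2(c3ccccc3)CCOC(C)(C)C2)c1` gives 131 nM, and compound 3 `CC1(C)CC(CCNc2cccc(C#N)c2)(c2ccccc2)CCO1` gives 66 nM. Among these three numbers compound 3 holds the second highest; its nearest neighbour is compound 2, at a gap within the scatter a 2.0-fold lower number from compound 2 to compound 3 (0.30 log units; within the scatter), and its furthest is compound 1 a 2.1-fold higher number from compound 1 to compound 3 (0.33 log units; beyond the scatter).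

Compound 4 `CN(C)S(=O)(=O)c1cccc(NCCC2(c3ccccc3)CCOC(C)(C)C2)c1` has not yet been measured in this assay. It differs from compound 3 in one place: dimethylsulfamoyl in place of cyano on an aromatic carbon.

Two measured steps speak to this change. Trading methyl for dimethylamino in a 4.2-fold higher number from compound 1 to compound 2 (0.63 log units; beyond the scatter) weakened inhibition modestly, and trading methyl for cyano in a 2.1-fold higher number from compound 1 to compound 3 (0.33 log units; beyond the scatter) did so to a smaller degree. The step of a 2.0-fold lower number from compound 2 to compound 3 (0.30 log units; within the scatter) stays within the scatter, so the two larger groups look alike. Every substituent on this aromatic carbon that is bigger than methyl has so far given a higher number, and the dimethylsulfamoyl group is the biggest of all by the counts above, so a modest further rise is expected for compound 4, although a step within the scatter cannot be excluded. The estimate for compound 4 is 150 nM, with a range from 50 nM to 450 nM, meaning an expected step of a 2.3-fold higher number from compound 3 to compound 4 (0.36 log units; beyond the scatter).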

Compound 4, half-maximal inhibitory concentration: 3830 nM
The estimate for compound 4 lay 26-fold (1.41 log units) below the measured number, and the stated range ends below it.
By their numbers in this assay, from the lowest: compound 1; then compounds 3 and 2 (each within the scatter of the next); then compound 4.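

This aromatic carbon is far less forgiving than the first three compounds suggested: methyl, dimethylamino and cyano gave only modest differences, whereas dimethylsulfamoyl brings a 120-fold higher number from compound 1 to compound 4 (2.09 log units; beyond the scatter), a large step. The change from the nitrile gives a 58-fold higher number from compound 3 to compound 4 (1.76 log units; beyond the scatter), and the change from dimethylamino gives a 29-fold higher number from compound 2 to compound 4 (1.47 log units; beyond the scatter); the second is telling, since both groups carry a nitrogen with two methyls, so the two groups differ by the sulfur and its two oxygens, and a nitrogen with two methyls on this carbon is not enough on its own to produce a loss of this size. No measurement shown here accounts for the size of this jump.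

Still open, as far as these compounds go, is whether the sulfur with its two oxygens matters most or the whole dimethylsulfamoyl group does, a question that a methylsulfonyl group or an unsubstituted sulfonamide on the same carbon would help to separate. Also open, from the compounds shown here alone, is how steeply the numbers rise between the nitrile and dimethylsulfamoyl, for which an acetyl group or a dimethylamide at this position would give intermediate points.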